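Hydroxymethyl on two related cores, one measured precedent

The source may hold more compounds than are shown below. What is called first, only, known or untested is meant among the compounds shown, and "the series" means these compounds.

Compound 1 `Oc1cc2c(cc1CNc1ccccc1)OCCC2` serves as the reference point of the set. In a functional assay for inhibition, with Homo sapiens as the target (on this read-out higher numbers stand for weaker inhibition and lower numbers for stronger inhibition), compound 1 gives 1700 nM. Compound 2 `OCc1ccccc1NCc1cc2c(cc1O)CCCO2` differs from compound 1 only by hydroxymethyl in place of hydrogen on an aromatic carbon; in this assay compound 2 gives 21000 nM, and the step is a 12-fold higher number from compound 1 to compound 2 (1.09 log units; beyond the scatter). Compound 3 `Oc1cc2c(cc1CNc1ccccc1)OCC2` is built on a second core, and the difference between the two cores is not broken down here. In this assay compound 3 gives 490 nM, the lowest of the three measured numbers, with compound 1 nearest to it and compound 2 furthest away, both gaps beyond the scatter.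

Compound 4 `OCc1ccccc1NCc1cc2c(cc1O)CCO2` has not been measured. It stands to compound 3 as compound 2 stands to compound 1: the change is hydroxymethyl in place of hydrogen on an aromatic carbon, the same change at the same kind of place on the second core. Within the data shown here, only one measured instance of this change exists, so any expectation rests on a single pair and carries the uncertainty of that.

The step from compound 3 to compound 4 is expected to be about a 10-fold higher number from compound 3 to compound 4 (1.01 log units; beyond the scatter) because the change repeats the one behind a 12-fold higher number from compound 1 to compound 2 (1.09 log units; beyond the scatter). Compound 4 is therefore estimated at 5000 nM in this assay, with a likely range from 1500 nM to 17000 nM, the width reflecting that the transfer of one step across two different cores is unverified.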

Compound 4, half-maximal inhibitory concentration: 11000 nM
The estimate for compound 4 lay 2.2-fold (0.34 log units) below the measured number; low and high end bracket the measured number.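

In this assay, hydroxymethyl in place of hydrogen on an aromatic carbon, ortho to a large group, again moves the number upward on the second core, with a 22-fold higher number from compound 3 to compound 4 (1.35 log units; beyond the scatter) and thus clearly weaker inhibition after the change. Set side by side, the two steps agree in direction and cannot be told apart in size: the same change on two cores in this assay, a 12-fold higher number (1.09 log units; beyond the scatter) from compound 1 to compound 2 and a 22-fold higher number (1.35 log units; beyond the scatter) from compound 3 to compound 4, 1.8-fold (0.26 log units) apart, within the scatter of two such steps. For this series, the change therefore carried over between these two cores with a similar penalty, but two matched pairs show neither that it would do so on a third core nor why the inhibition weakens.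

The compounds shown test only hydroxymethyl at this one kind of place, so they leave open whether a smaller or longer substituent, such as methyl or a hydroxyethyl chain, or a different function, such as an amine or a carboxylic acid, would carry the same penalty. They also leave open whether hydroxymethyl elsewhere on the same six-membered aromatic ring would give a step of this size on either core.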